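The source may report more compounds than this note shows. Statements on the series, on what has been measured and on what is new or still open speak of the compounds shown alone.

The measured compounds and their results in a functional assay on HepG2 cells (Homo sapiens) for cytotoxicity, read by MTT assay, with a stated time of 48 h; on this read-out lower numbers stand for stronger inhibition and higher numbers for weaker inhibition:

Compound 1 `CCCCCCOc1ccc2c(Cl)ccnc2c1`: 2420 nM
Compound 2 `CC(C)COc1ccc2c(Cl)ccnc2c1`: 2250 nM
Compound 3 `CCCCCCOc1ccc2c(NCCN(C)C)ccnc2c1`: 1370 nM

Compound 1 carries the highest of the three numbers, yet neither step away from it crosses the scatter: the step of a 1.1-fold lower number from compound 1 to compound 2 (0.03 log units; within the scatter) is the smaller, and the step of a 1.8-fold lower number from compound 1 to compound 3 (0.25 log units; within the scatter) the larger. Compound 4 `Clc1ccnc2cc(OCCc3ccccc3)ccc12` differs from compound 1 at the chain on the oxygen of the shared core: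

phenyl in place of butyl on a saturated chain carbon, two bonds along the chain from an oxygen on an aromatic ring

Going by the values given here, only the step from compound 1 to compound 2 bears on this change, as it also alters the chain on the saturated carbon bound to the aromatic oxygen, and it was a 1.1-fold lower number from compound 1 to compound 2 (0.03 log units; within the scatter), within the scatter. Among the compounds with values here, no measured step brings a phenyl onto that chain, so nothing in the data speaks for a shift beyond the scatter in this assay. Compound 4 is therefore expected to give 2000 nM, with a range of 900 nM to 4500 nM, which means an expected step of a 1.2-fold lower number from compound 1 to compound 4 (0.08 log units; within the scatter).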

Compound 4, half-maximal inhibitory concentration: 3310 nM
The estimate for compound 4 lay 1.7-fold (0.22 log units) below the measured number; the range from low to high includes it.
By their numbers in this assay, from the lowest: compounds 3, 2, 1 and 4 (each within the scatter of the next, the first and the last beyond it).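

In this assay the earlier step at this chain only swapped one saturated group for another, whereas this one places a six-membered aromatic ring of carbon on the chain, and it reads as a 1.4-fold higher number from compound 1 to compound 4 (0.14 log units; within the scatter). Within the compounds shown, then, phenyl in place of butyl at this place on the chain leaves the number inside the scatter, as the saturated change did. No measurement shown here bears on why the number stays there.

On these data alone, whether an amine or a carboxylic acid at the end of this chain, or a longer chain carrying the phenyl, would move the number beyond the scatter remains open. So does whether phenyl at this place would give a similar step on a compound carrying (2-(dimethylamino)ethyl)amino in place of chloro.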